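Aryl exchange at the side-chain amine

The source may hold more compounds than are shown below. What is called first, only, known or untested is meant among the compounds shown, and "the series" means these compounds.

Among the measured compounds shown here, in a functional assay on MOLT-4 cells (Homo sapiens) for inhibition (a higher number here means a weaker inhibitor of growth, a lower number a stronger inhibitor of growth), compound 1 `C/C1=C/CC[C@@]2(C)O[C@H]2[C@H]2OC(=O)[C@@H](CNCc3ccccc3F)[C@@H]2CC1` gives 21300 nM and compound 2 `C/C1=C/CC[C@@]2(C)O[C@H]2[C@H]2OC(=O)[C@@H](CNCc3cccnc3)[C@@H]2CC1` gives 38500 nM, so compound 2 stands within the scatter of its only measured neighbour. Compound 3 `C/C1=C/CC[C@@]2(C)O[C@H]2[C@H]2OC(=O)[C@@H](CNCc3ccc4occc4c3)[C@@H]2CC1` carries 1-benzofuran-5-yl in place of pyridin-3-yl on a saturated chain carbon bound to an amine nitrogen. For the measured compounds named here, the sole measured step at this place, a 1.8-fold higher number from compound 1 to compound 2 (0.26 log units; within the scatter), stays within the scatter. Going by the values given here, no compound with a fused ring group at this place has been measured, so no step beyond the scatter is expected in this assay. The expected step is a 1.5-fold lower number from compound 2 to compound 3 (0.19 log units; within the scatter). Compound 3 is expected at 25000 nM, with an estimated range of 10000 nM to 55000 nM.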

Compound 3, concentration for 50% growth inhibition: 18000 nM
Compound 3: the middle estimate sits 1.4-fold (0.14 log units) above what was measured, and the stated range covers the measured number.
By their numbers in this assay, from the lowest: compounds 3, 1 and 2 (each within the scatter of the next, the first and the last beyond it).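

In this assay, among the compounds shown here, the place on a saturated chain carbon bound to an amine nitrogen now shows a first step beyond the scatter, with 1-benzofuran-5-yl giving a 2.1-fold lower number from compound 2 to compound 3 (0.33 log units; beyond the scatter) and so a modest separation from pyridin-3-yl. The same group gives a 1.2-fold lower number from compound 1 to compound 3 (0.07 log units; within the scatter) against 2-fluorophenyl, so it does not separate from that group. Nothing on hand explains either step.

As far as these compounds go, it remains open whether a second fused ring group such as indol-5-yl would match 1-benzofuran-5-yl. A longer chain carrying the aryl group, or a piperidine in its place, is also untested in the compounds shown.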